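A Trimethoxyphenyl Swap on the Shared Core

A few compounds are considered here, and "the series" means these few. Any claim that something is new, unique, unknown or untested is made for them only; others in the source may bear on it.

Compound 1, `CC(C)c1ccc(-c2nc(SCc3cn(CC(=O)NC(=O)Nc4ccccn4)nn3)nc(Nc3ccc(Cl)cc3)c2C#N)cc1`: 11200 nM
Compound 2, `Cc1ccc(Nc2nc(SCc3cn(CC(=O)NC(=O)Nc4ccccn4)nn3)nc(-c3ccc(C(C)C)cc3)c2C#N)cc1`: 6700 nM
Compound 3, `Cc1ccccc1Nc1nc(SCc2cn(CC(=O)NC(=O)Nc3ccccn3)nn2)nc(-c2ccc(C(C)C)cc2)c1C#N`: 7230 nM

In a functional assay on ECa-109 cells (Homo sapiens) for inhibition, read by MTT assay, with a stated time of 72 h (a higher number here means a weaker inhibitor, a lower number a stronger inhibitor), compound 2 gives the lowest of the three numbers, yet a 1.1-fold higher number from compound 2 to compound 3 (0.03 log units; within the scatter) and a 1.7-fold lower number from compound 1 to compound 2 (0.22 log units; within the scatter) both fall within the scatter, so the three measured compounds cannot be told apart on these data. The third step, a 1.5-fold lower number from compound 1 to compound 3 (0.19 log units; within the scatter), is likewise within the scatter.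

Compound 4, `COc1cc(-c2nc(SCc3cn(CC(=O)NC(=O)Nc4ccccn4)nn3)nc(Nc3ccc(C)cc3)c2C#N)cc(OC)c1OC`, has not yet been measured. It differs from compound 2 in one place: 3,4,5-trimethoxyphenyl in place of 4-isopropylphenyl on an aromatic carbon. All three measured steps change only the aryl group on the nitrogen, leaving the aryl group on the aromatic carbon untouched, so none of them bears on this change. There is no measured guide for the direction of this swap, and the expectation rests solely on the closeness of the three numbers already seen. Compound 4 is therefore expected to land near compound 2, with a 1.3-fold lower number from compound 2 to compound 4 (0.13 log units; within the scatter), and its value in this assay is estimated at 5000 nM, within a wide range from 900 nM to 28000 nM.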

Compound 4, half-maximal inhibitory concentration: 21300 nM
Compound 4: middle estimate off by 4.3-fold (0.63 log units), on the low side; low and high end bracket the measured number.
By their numbers in this assay, from the lowest: compounds 2, 3, 1 and 4 (each within the scatter of the next, the first and the last beyond it).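

Among these compounds, every earlier step changed the aryl group on the nitrogen and stayed within the scatter, whereas this change, on the aromatic carbon next to the ring nitrogen and ortho to a cyano group, is the first to go beyond it in this assay, with a 3.2-fold higher number from compound 2 to compound 4 (0.50 log units; beyond the scatter). In this one pair, 3,4,5-trimethoxyphenyl in place of 4-isopropylphenyl gives the weaker inhibitor, so the number does respond to the group at this carbon, though the step is modest. Nothing measured here offers an explanation for this step.

The compounds shown leave open how a plain phenyl or a 4-methoxyphenyl group would read at this carbon. They also leave open whether the same step would appear with 4-chlorophenyl or 2-methylphenyl on the nitrogen.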